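The source may report more compounds than this note shows. Statements on the series, on what has been measured and on what is new or still open speak of the compounds shown alone.

Working notes on the series. In an ADME assay on HepG2 cells (Homo sapiens) for cytotoxicity, read by luminescence, CellTiter-Glo and ATP content, with a stated time of 72 h (on this read-out lower numbers stand for an effect already at smaller amounts and higher numbers for an effect only at larger amounts of compound), compound 1 `COc1ccccc1Oc1ccc2c(NCCCNCc3ccco3)ccnc2c1` gives 6500 nM. Among the three compounds measured so far it stands second highest: compound 3 `COc1ccc(F)cc1CNCCCNc1ccnc2cc(Cc3ccccc3)ccc12` gives 7990 nM, a gap within the scatter, while compound 2 `CCC(CC)c1ccc2c(NCCCNCc3cccc(OC)c3O)ccnc2c1` gives 410 nM, a gap well beyond the scatter. Compound 4 `Fc1ccc(Cc2ccc3c(NCCCNCc4ccco4)ccnc3c2)cc1` has not yet been measured. It differs from compound 1 in one place: 4-fluorobenzyl in place of 2-methoxyphenoxy on an aromatic carbon. Among the compounds with values here, no step between measured compounds that differ in a single place is available, so the size of the step cannot be read off directly; compound 3 carries a closely related group on its core and sits within the scatter of compound 1, though it differs elsewhere as well. For compound 4 no step beyond the scatter is expected, a 1.1-fold lower number from compound 1 to compound 4 (0.03 log units; within the scatter). The value expected for compound 4 is 6000 nM, within a range from 2000 nM to 16000 nM.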

Compound 4, half-maximal effective concentration: 5600 nM
For compound 4 the middle estimate is 1.1-fold (0.03 log units) above the measured one, and the stated range covers the measured number.
By their numbers in this assay, from the lowest: compound 2; then compounds 4, 1 and 3 (each within the scatter of the next).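

In this assay this position now has its first single-place step (a 1.2-fold lower number from compound 1 to compound 4 (0.06 log units; within the scatter)): 4-fluorobenzyl in place of 2-methoxyphenoxy on an aromatic carbon stays within the scatter, although the entering group has no hydrogen-bond acceptors and the leaving group has 2. No available measurement bears on the reason for this result. The compounds shown leave open what a carboxylic acid or an amine on this aromatic carbon would give, and whether this exchange gives a step of similar size when the furan-2-ylmethyl group of compound 4 is replaced.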